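A few compounds are considered here, and "the series" means these few. Any claim that something is new, unique, unknown or untested is made for them only; others in the source may bear on it.

Measured in an ADME assay (liver) for metabolic stability, with Liver microsome (Rattus norvegicus) as the target, using microsomes and NADPH, with a stated time of 30 min, at 37 degrees C, tested at 1 uM; a lower number here means slower removal, a higher number faster removal of the compound:
- Compound 1 `C[C@@](O)(c1ccc(-c2ncc(S(=O)(=O)c3ccc(N)nc3)s2)c(Cl)c1)C(F)(F)F`: < 14 mL.min-1.g-1, a limit
- Compound 2 `CC(C)(O)c1ccc(-c2ncc(S(=O)(=O)c3ccc(N)nc3)s2)c(Cl)c1`: 17 mL.min-1.g-1
- Compound 3 `CC(O)(CO)c1ccc(-c2ncc(S(=O)(=O)c3ccc(N)nc3)s2)c(Cl)c1`: < 14 mL.min-1.g-1, a limit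

Compound 3 has only a limit and no exact number, and it stands at the limit of < 14 mL.min-1.g-1 in this assay, at which 2 of the 3 values shown sit. Compound 4 `C[C@](O)(CO)c1ccc(-c2ncc(S(=O)(=O)c3ccc(N)nc3)s2)c(Cl)c1` differs from it in one way: the two compounds have the same atoms and bonds; at least one stereo element is drawn with a configuration in one of them and without one in the other: 1 of 1 stereo elements differ; a stereocentre at a saturated chain carbon is drawn without a configuration in compound 3 and R in compound 4.

Two measured steps offer the nearest guide: an at least 1.2-fold lower number from compound 2 to compound 3 (0.08 log units; that floor lies within the scatter), and an at least 1.2-fold higher number from compound 1 to compound 2 (0.08 log units; that floor lies within the scatter). Both change atoms of the side chain, and neither tests a drawn configuration. They therefore give no reason to expect a change beyond the scatter in this assay. The expected step is a step that the limit leaves unreadable from compound 3 to compound 4. The estimate for compound 4 is 13 mL.min-1.g-1, with an expected range from 9 mL.min-1.g-1 to 20 mL.min-1.g-1.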

Compound 4, intrinsic clearance in microsomes: < 14 mL.min-1.g-1
Compound 4 ended at the assay's limit; the forecaster's own chance of this, stated with the estimate: 65%; the middle value is on the limit's open side.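

In this assay, the R form, compound 4, ends at a limit just as compound 3 does, so neither compound can be ranked against the other, and the steps to compound 4 from compound 1 and compound 3 cannot be read: the limit of < 14 mL.min-1.g-1 in this assay, at which 3 of the 4 values shown sit. This comparison of configuration also has an unequal basis: the fact that one of compounds 3 and 4 is drawn with a defined configuration and the other without, at the place where they differ. Among the compounds shown here, the one readable step is an at least 1.2-fold lower number from compound 2 to compound 4 (0.08 log units; that floor lies within the scatter).

From the compounds shown here alone, what remains open is how the S form would compare with the R form, and how an amine or a carboxylic acid would behave in place of the hydroxymethyl.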